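Pyridin-4-yl to pyrimidin-5-yl swap: transferring one step

The compounds below may be only part of what the source reports. "The series", "measured", "known", "first", "only" and "open" are said of these compounds alone.

Compound 1 `COc1cccc(S(=O)(=O)/C=C/c2ccncc2)c1` and compound 2 `COc1ccc(S(=O)(=O)/C=C/c2ccncc2)cc1` are built from the same atoms joined differently; the difference between the two cores is not broken down here. In an assay on U2OS cells for activation of nuclear factor erythroid 2-related factor 2 (Homo sapiens), read by chemiluminescence, with a stated time of 6 h (on this read-out higher numbers stand for an effect only at larger amounts of compound and lower numbers for an effect already at smaller amounts), compound 1 gives 655 nM and compound 2 gives 1200 nM, a gap that stays within the usual scatter. Compound 3 `COc1cccc(S(=O)(=O)/C=C/c2cncnc2)c1` differs from compound 1 by pyrimidin-5-yl in place of pyridin-4-yl on a double-bonded chain carbon bound to a double-bonded chain carbon and in this assay compound 3 gives 7380 nM, so the step of an 11-fold higher number from compound 1 to compound 3 (1.05 log units; beyond the scatter) is a large loss. Compound 4 `COc1ccc(S(=O)(=O)/C=C/c2cncnc2)cc1` is not yet measured; it differs from compound 2 by pyrimidin-5-yl in place of pyridin-4-yl on a double-bonded chain carbon bound to a double-bonded chain carbon, the same change at the same place. The expected step is an 11-fold higher number from compound 2 to compound 4 (1.03 log units; beyond the scatter) because the identical change gave an 11-fold higher number from compound 1 to compound 3 (1.05 log units; beyond the scatter). Compound 4 is therefore estimated at 13000 nM in this assay, with a likely range from 5000 nM to 35000 nM.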

Compound 4, half-maximal effective concentration: > 10000 nM
Compound 4 was reported as a limit; the forecaster's own chance of this, stated with the estimate: 10%; the middle value lies beyond the limit too.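

In this assay compound 4 gives > 10000 nM, which is a limit of the assay and not a number. On the core of compound 2, pyrimidin-5-yl in place of pyridin-4-yl gives an at least 8.3-fold higher number from compound 2 to compound 4 (0.92 log units; beyond the scatter), so the loss seen on the core of compound 1 carries over in direction to this second core. Whether it also carries over in size is not shown: the same change on two cores in this assay, an 11-fold higher number (1.05 log units; beyond the scatter) from compound 1 to compound 3 and an at least 8.3-fold higher number (0.92 log units; beyond the scatter) from compound 2 to compound 4; the limit leaves it open whether they differ

Open, going by these compounds, is how an amine or a carboxylic acid added to pyridin-4-yl would behave in this assay. Also open, on these data alone, is whether the same swap gives the same loss on any core beyond these two.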